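The source may hold more compounds than are shown below. What is called first, only, known or untested is meant among the compounds shown, and "the series" means these compounds.

Of the compounds shown here, three of a shared core have been measured in a functional assay for inhibition, with Homo sapiens as the target; on this read-out higher numbers stand for weaker inhibition and lower numbers for stronger inhibition. Compound 1, `CN(C)CCCOc1ccc(Nc2nccc(-c3cccnc3)n2)cc1`, gives 600 nM, the lowest of the three numbers. Compound 2, `Oc1ccc(Nc2nccc(-c3ccncc3)n2)cc1`, gives 3300 nM, and compound 3, `Cc1cccc(Nc2nccc(-c3ccncc3)n2)c1`, gives 8800 nM; both numbers lie well above that of compound 1, beyond the usual scatter. The next compound, compound 4, `CC1CCN(c2ccc(Nc3nccc(-c4cccnc4)n3)cc2)CC1`, has not yet been measured. It differs from compound 1 in one place: 4-methylpiperidin-1-yl in place of 3-(dimethylamino)propoxy on an aromatic carbon. For the measured compounds named here, no measured pair shows a change of this kind, so no firm direction can be read from the data. The step from compound 1 to compound 4 is expected to be modest and, if anything, toward a higher number, a 2.0-fold higher number from compound 1 to compound 4 (0.30 log units; within the scatter). Compound 4 is therefore estimated at 1200 nM, within a range from 300 nM to 5000 nM.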

Compound 4, half-maximal inhibitory concentration: 500 nM
Compound 4: the middle estimate sits 2.4-fold (0.38 log units) above what was measured, within the range that was stated.
By their numbers in this assay, from the lowest: compounds 4 and 1 (each within the scatter of the next); then compound 2; then compound 3.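

In this assay, replacing 3-(dimethylamino)propoxy with 4-methylpiperidin-1-yl on this aromatic carbon gives a 1.2-fold lower number from compound 1 to compound 4 (0.08 log units; within the scatter) and so leaves the read-out within the scatter. At this position, therefore, a chain without a ring and a six-membered non-aromatic ring of the same heavy-atom count give values that cannot be told apart. Nothing available bears on why these two groups read alike.

The compounds shown leave open how a morpholine, a piperazine or an unsubstituted piperidine would read at this position. They also leave open how a shorter chain ending in an amine would read there.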